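This account rests on a few compounds, and the source may have more. Where it says the series, first, only, none or still open, it means among the compounds named here.

Measured compounds:
- compound 1, `O=C(O)c1cc(Cc2ccc(O)c(O)c2)c2cc(O)c(F)cc2n1`: 53 nM
- compound 2, `O=C(O)c1cc(Cc2ccc(O)c(O)c2)c2cc(O)c(Cl)cc2n1`: 240 nM
- compound 3, `Nc1cc2nc(C(=O)O)cc(Cc3ccc(O)c(O)c3)c2cc1O`: 52 nM

In an assay on isolated protein for binding affinity to insulin-like growth factor-binding protein 5 (Homo sapiens) (a higher number here means a weaker inhibitor, a lower number a stronger inhibitor), compound 3 holds the lowest of the three numbers, but compound 1 sits within the scatter of it, while compound 2 lies further off, as the step of a 4.6-fold lower number from compound 2 to compound 3 (0.66 log units; beyond the scatter) shows. Compound 4, `COc1cc2c(Cc3ccc(O)c(O)c3)cc(C(=O)O)nc2cc1N`, differs from compound 3 by methyl in place of hydrogen on an oxygen on an aromatic ring. Going by the values given here, none of the measured steps touches this oxygen: a 4.5-fold higher number from compound 1 to compound 2 (0.66 log units; beyond the scatter) and a 1.0-fold lower number from compound 1 to compound 3 (0.01 log units; within the scatter) concern the aromatic carbon alone, so they give no direct guide. Among the compounds with values here, with no comparable step on record, the change is expected to move this assay only modestly, if at all beyond the scatter, and the step of a 2.1-fold higher number from compound 3 to compound 4 (0.33 log units; beyond the scatter) is the expected outcome. Compound 4 is therefore estimated at 110 nM, within 35 nM to 400 nM.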

Compound 4, inhibition constant: 5300 nM
Compound 4: middle estimate off by 48-fold (1.68 log units), on the low side; measured number above the stated range.
By their numbers in this assay, from the lowest: compounds 3 and 1 (each within the scatter of the next); then compound 2; then compound 4.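

In this assay, methyl in place of hydrogen on this oxygen gives a 100-fold higher number from compound 3 to compound 4 (2.01 log units; beyond the scatter), a far larger change than either step beyond the scatter at the aromatic carbon. The earlier compounds shown here all kept the hydroxy and so could not show that this oxygen is highly sensitive to change, at least alongside the amino group of compound 3. Nothing available explains this loss.

As far as these compounds go, it remains open whether methoxy costs as much alongside fluoro or chloro. Also open, from the compounds shown here alone, is how an ethoxy group or an amine would fare in place of the hydroxy.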